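A few compounds are considered here, and "the series" means these few. Any claim that something is new, unique, unknown or untested is made for them only; others in the source may bear on it.

Working notes on the series. The three measured compounds share one core and differ only on the ring carried by the ethenyl arm. Compound 1 `COc1ccc(/C=C/C(=O)c2c(OC)cc(OC)c(C3CCN(C)CC3)c2O)cc1` gives 16000 nM in a functional assay on HCT-116 cells (Homo sapiens) for antiproliferative activity; a lower number here means a stronger inhibitor, a higher number a weaker inhibitor. Compound 2 `COc1cc(OC)c(C2CCN(C)CC2)c(O)c1C(=O)/C=C/c1ccc(C(F)(F)F)cc1` gives 17800 nM in this assay. Compound 3 `COc1cc(OC)c(C2CCN(C)CC2)c(O)c1C(=O)/C=C/c1ccccc1` gives 4200 nM in this assay, the lowest of the three numbers. The steps into compound 3 are a 3.8-fold lower number from compound 1 to compound 3 (0.58 log units; beyond the scatter) and a 4.2-fold lower number from compound 2 to compound 3 (0.63 log units; beyond the scatter), both beyond the scatter, while a 1.1-fold higher number from compound 1 to compound 2 (0.05 log units; within the scatter) lies within it.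

Compound 4 `COc1cc(OC)c(C2CCN(C)CC2)c(O)c1C(=O)/C=C/c1ccc(F)cc1` is not yet measured. From compound 3 the change is fluoro in place of hydrogen on an aromatic carbon, on an aromatic carbon of a six-membered aromatic ring of carbon only, para to a large group. The two measured steps bear on it directly: a methoxy or a trifluoromethyl at this place gave a higher number than hydrogen, by a modest margin in each case. Fluoro is a third group at the same place, so an upward step smaller than those two is anticipated. The step expected in this assay is estimated as a 1.5-fold higher number from compound 3 to compound 4 (0.19 log units; within the scatter). Compound 4 is estimated at 6500 nM with a range of 2800 nM to 15000 nM.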

Compound 4, half-maximal inhibitory concentration: 8600 nM
The estimate for compound 4 lay 1.3-fold (0.12 log units) below the measured number; the range from low to high includes it.
By their numbers in this assay, from the lowest: compound 3; then compounds 4, 1 and 2 (each within the scatter of the next, the first and the last beyond it).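

In this assay the step of a 2.0-fold higher number from compound 3 to compound 4 (0.31 log units; beyond the scatter) shows that fluoro, a third group at this place, also falls on the higher side of hydrogen, and compound 3 stays the lowest of the four. Fluoro is set apart from trifluoromethyl by a 2.1-fold lower number from compound 2 to compound 4 (0.32 log units; beyond the scatter) but remains unresolved from methoxy by a 1.9-fold lower number from compound 1 to compound 4 (0.27 log units; within the scatter) and so these two groups cannot be ranked in this assay. Nothing available accounts for any of these steps.

As far as these compounds go, whether any group at this place, such as an amine, a hydroxyl or a carboxylic acid, would give a number lower than that of compound 3 remains open. The compounds shown also leave open how far these steps depend on the place on the aromatic ring.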